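From Methyl to Ethyl on a Shared Core

The source may hold more compounds than are shown below. What is called first, only, known or untested is meant among the compounds shown, and "the series" means these compounds.

Measured compounds:
compound 1 `CCCCCCNC(=O)n1cc(F)c(=O)n(C)c1=O` — 13 nM
compound 2 `CCCCCCNC(=O)n1ccc(=O)n(C)c1=O` — 53 nM

In an assay on HEK293 cells for inhibition of acid ceramidase (Rattus norvegicus), read by LC-MS, with a stated time of 30 min (a lower number here means a stronger inhibitor, a higher number a weaker inhibitor), compound 1 gives 13 nM, the lowest of the two numbers recorded. Among the measured compounds shown here, its only measured neighbour is compound 2, which in this assay gives 53 nM. For the measured compounds named here, the one step between them, a 4.1-fold higher number from compound 1 to compound 2 (0.61 log units; beyond the scatter), comes from hydrogen in place of fluoro on an aromatic carbon, and compound 3 keeps that fluoro.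

Compound 3 `CCCCCCNC(=O)n1cc(F)c(=O)n(CC)c1=O` differs from compound 1 by methyl in place of hydrogen on a saturated chain carbon bound to an aromatic nitrogen; cut one bond further out, the change reads methyl to ethyl. Going by the values given here, no measured step touches this place on the core: the sole step, a 4.1-fold higher number from compound 1 to compound 2 (0.61 log units; beyond the scatter), concerns a different position, and nothing among the measured compounds shows what lengthening the chain on the aromatic nitrogen does. With no evidence either way, the expectation is a step within the scatter, carrying the potency of compound 1 over largely unchanged. Compound 3 is therefore expected in this assay at about 15 nM, within a range from 5 nM to 45 nM. The step this expectation implies, a 1.2-fold higher number from compound 1 to compound 3 (0.06 log units; within the scatter), would lie within the usual scatter, in either direction.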

Compound 3, half-maximal inhibitory concentration: 18 nM
Beside the measured number, compound 3's estimate is 1.2-fold (0.08 log units) below it, within the range that was stated.
By their numbers in this assay, from the lowest: compounds 1 and 3 (each within the scatter of the next); then compound 2.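

Among the compounds shown here, this is the first reading at the chain on the aromatic nitrogen. In this assay, for the compounds shown here, the step of a 1.4-fold higher number from compound 1 to compound 3 (0.14 log units; within the scatter) shows that methyl in place of hydrogen on a saturated chain carbon bound to an aromatic nitrogen, read one bond further out as methyl to ethyl, leaves the number within the scatter, so on the fluoro-bearing core of compound 1 methyl and ethyl at this place cannot be told apart, whereas the only earlier step (a 4.1-fold higher number from compound 1 to compound 2 (0.61 log units; beyond the scatter)), at the fluoro, lies beyond the scatter. Nothing measured here bears on why the two numbers agree.

The compounds shown leave open whether a longer chain at this place, such as propyl or butyl, or a chain ending in an amine or a carboxylic acid, would also stay within the scatter of compound 1. Going by these compounds alone, they also leave open whether methyl to ethyl reads the same on the core of compound 2, which has hydrogen in place of the fluoro, as only one step at this place can be read so far.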